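Lengthening the amine-bearing chain on the triazole of compound 1

The compounds below may be only part of what the source reports. "The series", "measured", "known", "first", "only" and "open" are said of these compounds alone.

Compound 1 `CN(C)CCn1cnnc1-c1cc(Oc2ccc(NC(=O)Nc3ccccc3C(F)(F)F)cc2F)ccn1` was tested in an ADME assay on WI-38 cells (Homo sapiens) for cytotoxicity, read by MTT assay, with a stated time of 72 h; on this read-out lower numbers stand for stronger inhibition and higher numbers for weaker inhibition. In this assay compound 1 gives > 50000 nM, which is a limit of the assay rather than a number (the limit of > 50000 nM in this assay, at which 1 of the 2 values shown sits). For the measured compounds named here, compound 2 `CN(C)CCn1cnnc1-c1cc(Oc2ccc(NC(=O)Nc3ccc(Cl)cc3Cl)cc2F)ccn1` gives 10400 nM in this assay, and the single measured step, an at least 4.8-fold lower number from compound 1 to compound 2 (0.68 log units; beyond the scatter), concerns the aryl urea end of the molecule. Compound 3 `CN(C)CCCn1cnnc1-c1cc(Oc2ccc(NC(=O)Nc3ccccc3C(F)(F)F)cc2F)ccn1` differs from compound 1 in another place: (dimethylamino)methyl in place of dimethylamino on a saturated chain carbon, two bonds along the chain from an aromatic nitrogen. Going by the values given here, no measured step touches this chain, so the one known step gives no direct guide, and the change is small in counted atoms. He therefore expects no step beyond the scatter in this assay, with a number no higher from compound 1 to compound 3 (the limit leaves the size open) as the estimated step. Compound 3 is estimated at 50000 nM, within a range from 15000 nM to 150000 nM, most likely again a limit.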

Compound 3, half-maximal inhibitory concentration: 28600 nM
The estimate for compound 3 lay 1.7-fold (0.24 log units) above the measured number, within the range that was stated.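

For the compounds shown here, with 3-(dimethylamino)propyl in place of 2-(dimethylamino)ethyl, in this assay compound 3 gives 28600 nM, a measured number, and this is the first reading at this chain position, which the earlier step at the aryl urea end did not touch. Compound 1 remains a limit of the assay and not a number: the limit of > 50000 nM in this assay, at which 1 of the 3 values shown sits. The step is an at least 1.7-fold lower number from compound 1 to compound 3 (0.24 log units; that floor lies within the scatter), so it gives only a floor, and the true size of the change from lengthening the chain cannot be read.

The compounds shown leave open how a longer chain such as 4-(dimethylamino)butyl, or a morpholine in place of dimethylamino, would read in this assay. They also leave open how the 3-(dimethylamino)propyl chain would read together with the 2,4-dichlorophenyl group of compound 2.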